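Alpha-substituent variation on the shared amide core

The source may hold more compounds than are shown below. What is called first, only, known or untested is meant among the compounds shown, and "the series" means these compounds.

Measured compounds:
compound 1 `CCC(C(=O)NCc1ccc(C(F)(F)F)nc1N1CCC(C)CC1)c1ccc(NS(C)(=O)=O)c(F)c1`: 1.6 nM
compound 2 `Cc1ccccc1C(C(=O)NCc1ccc(C(F)(F)F)nc1SC1CCCCC1)c1ccc(NS(C)(=O)=O)c(F)c1`: "active" (no number reported)
compound 3 `CS(=O)(=O)Nc1ccc(C(Cc2ccccc2)C(=O)NCc2ccc(C(F)(F)F)nc2SC2CCCCC2)cc1F`: "active" (no number reported)

For the measured compounds named here, in an assay on CHO cells for antagonist activity at transient receptor potential cation channel subfamily V member 1 (Homo sapiens), read by FLIPR (a lower number here means a stronger inhibitor, a higher number a weaker inhibitor), compound 1 gives 1.6 nM, the only number in the set. Going by the values given here, compound 2 is reported as "active" (no number reported) and compound 3 as "active" (no number reported), without figures, so no step between measured compounds can be sized. Compound 4 `CC1CCN(c2nc(C(F)(F)F)ccc2CNC(=O)C(Cc2ccc(F)cc2)c2ccc(NS(C)(=O)=O)c(F)c2)CC1` differs from compound 1 by 4-fluorophenyl in place of methyl on a saturated chain carbon, two bonds along the chain from an aromatic carbon and a carbonyl carbon; cut one bond further out, this reads ethyl to 4-fluorobenzyl. Compounds 2 and 3 show that an aryl or benzyl group on that chain carbon keeps activity, but give no scale. The step from compound 1 to compound 4 in this assay is expected to be small, at most a modest loss, a 1.9-fold higher number from compound 1 to compound 4 (0.27 log units; within the scatter). Compound 4 is estimated at 3 nM, in the range 0.8 nM to 12 nM.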

Compound 4, inhibition constant: 49.3 nM
Beside the measured number, compound 4's estimate is 16-fold (1.22 log units) below it, outside the stated range (above it).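

In this assay, 4-fluorobenzyl in place of ethyl on this saturated chain carbon is not a neutral change: it gives a 31-fold higher number from compound 1 to compound 4 (1.49 log units; beyond the scatter). For the compounds shown here, this is the first sized step at this position, and compound 4 still gives a measurable 49.3 nM. No measured data on hand account for the loss.

Steps involving compound 2 and compound 3 cannot be read. Still open, going by these compounds, is whether a propyl chain or an aminomethyl group on this carbon, on the core of compound 1, would stay close to compound 1.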